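Replacing thiophen-3-yl with cyclopropyl: an expected mouse dose

The source may hold more compounds than are shown below. What is called first, only, known or untested is meant among the compounds shown, and "the series" means these compounds.

Within the data shown here, in a functional assay on the whole organism with Mus musculus as the target (on this read-out higher numbers stand for an effect only at larger amounts of compound and lower numbers for an effect already at smaller amounts), compound 2 `C[C@@H](NCc1ccc(OCc2ccsc2)cc1)C(N)=O` gives 114 mg/kg and holds the highest of the two numbers so far, while compound 1 `C[C@@H](NCc1ccc(OCc2ccccc2)cc1)C(N)=O` gives 23.8 mg/kg as the lower one. Compound 3 `C[C@@H](NCc1ccc(OCC2CC2)cc1)C(N)=O` has cyclopropyl in place of thiophen-3-yl on a saturated chain carbon bound to an oxygen on an aromatic ring. Among the measured compounds shown here, only one measured step bears on this change, at the same place but with a different swap: a 4.8-fold higher number from compound 1 to compound 2 (0.68 log units; beyond the scatter) for thiophen-3-yl in place of phenyl. On these data alone, that single modest step sets no rule for cyclopropyl, so no step beyond the scatter is expected in this assay and the direction stays open. The expected change is a 1.4-fold lower number from compound 2 to compound 3 (0.15 log units; within the scatter) in size. Compound 3 is estimated at 80 mg/kg with 30 mg/kg to 200 mg/kg as the likely span.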

Compound 3, dose for half-maximal effect: 124 mg/kg
For compound 3 the middle estimate is 1.6-fold (0.19 log units) below the measured one; the range from low to high includes it.
By their numbers in this assay, from the lowest: compound 1; then compounds 2 and 3 (each within the scatter of the next).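

In this assay the swap from thiophen-3-yl to cyclopropyl on this saturated chain carbon leaves the number essentially unchanged (a 1.1-fold higher number from compound 2 to compound 3 (0.04 log units; within the scatter)), even though a non-aromatic carbon ring replaces a five-membered aromatic ring with a hetero atom. Compound 1, with phenyl, now stands apart from both other compounds (a 5.2-fold higher number from compound 1 to compound 3 (0.72 log units; beyond the scatter)). No available evidence explains this difference. Still open, on these data alone, is how a longer carbon chain, a pyridine ring or an amine at this place would compare with phenyl.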